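The source may hold more compounds than are shown below. What is called first, only, known or untested is meant among the compounds shown, and "the series" means these compounds.

Two compounds with a shared core have numbers in a functional assay on MIA PaCa-2 cells (Homo sapiens) for antiproliferative activity, read by sulforhodamine B assay, with a stated time of 48 h; on this read-out higher numbers stand for weaker inhibition and lower numbers for stronger inhibition. There, compound 1 `COc1ccc2nc(-c3ccc(N/C=C\C(=O)c4cc(OC)c(OC)c(OC)c4)cc3)sc2c1` gives 31100 nM and compound 2 `COc1ccc2nc(-c3ccc(N/C=C\C(=O)c4ccc(OC)c([N+](=O)[O-])c4)cc3)sc2c1` gives 23600 nM. These two values lie within the scatter of each other, so compound 2 cannot be told apart from compound 1 on these numbers. Compound 3 `COc1ccc2nc(-c3ccc(N/C=C\C(=O)c4cc(OC)c(OC)c([N+](=O)[O-])c4)cc3)sc2c1` is compound 2 with a single change: methoxy in place of hydrogen on an aromatic carbon, ortho to a methoxy group and meta to a nitro group. Among the compounds with values here, no measured step isolates this change. Compound 1, with its methoxy groups and no nitro group, gives 31100 nM, and compound 2 gives 23600 nM, so no shift beyond the scatter is expected in this assay. The expected 1.1-fold higher number from compound 2 to compound 3 (0.04 log units; within the scatter) stays within the scatter. The estimate for compound 3 is 26000 nM, with an expected range of 11000 nM to 50000 nM.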

Compound 3, half-maximal inhibitory concentration: 25600 nM
Estimate against measurement, compound 3: 1.0-fold (0.01 log units) above; the range from low to high includes it.
By their numbers in this assay, from the lowest: compounds 2, 3 and 1 (each within the scatter of the next).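

In this assay, methoxy in place of hydrogen on the aromatic carbon ortho to a methoxy group and meta to a nitro group gives a 1.1-fold higher number from compound 2 to compound 3 (0.04 log units; within the scatter), so this position accepts the added group without a difference that can be told from the scatter. The exchange of nitro in place of methoxy on an aromatic carbon can now be read directly, as a 1.2-fold lower number from compound 1 to compound 3 (0.08 log units; within the scatter), and compound 3 cannot be told apart from compound 1 either. No measurement is at hand that bears on why these values lie so close.

From the compounds shown here alone, it remains open whether an amine, a carboxylic acid or a longer chain at this position would give a number beyond the scatter. The compounds shown also leave open whether any change to the shared core away from this position would do so.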